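Methylphenyl triazoles on the shared core: a note

This account rests on a few compounds, and the source may have more. Where it says the series, first, only, none or still open, it means among the compounds named here.

Four compounds share one core and differ in where the methyl sits on the phenyl carried by the triazole nitrogen and in where the sulfonamide arm is joined. Compound 1 `Cc1ccccc1-n1cc(-c2cccc(NS(=O)(=O)c3c[nH]c(=O)[nH]c3=O)c2)nn1` in a functional assay on HepG2 cells (Homo sapiens) for antiproliferative activity, read by MTT assay, with a stated time of 24 h (on this read-out higher numbers stand for weaker inhibition and lower numbers for stronger inhibition), gives 9570 nM. Compound 2 `Cc1cccc(-n2cc(-c3cccc(NS(=O)(=O)c4c[nH]c(=O)[nH]c4=O)c3)nn2)c1` carries the change 3-methylphenyl in place of 2-methylphenyl on an aromatic nitrogen and in this assay gives 7050 nM; the step of a 1.4-fold lower number from compound 1 to compound 2 (0.13 log units; within the scatter) is small. Compound 3 `Cc1ccccc1-n1cc(-c2ccc(NS(=O)(=O)c3c[nH]c(=O)[nH]c3=O)cc2)nn1` in this assay gives 14500 nM; how its core differs from that of compound 1 is not broken down here. Compound 3 and compound 2 stand apart by more than the scatter, whereas compound 3 and compound 1 do not.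

Compound 4 `Cc1cccc(-n2cc(-c3ccc(NS(=O)(=O)c4c[nH]c(=O)[nH]c4=O)cc3)nn2)c1` is not yet measured. It stands to compound 3 as compound 2 stands to compound 1: the change (3-methylphenyl in place of 2-methylphenyl on an aromatic nitrogen), with the place described in the same words for both pairs, so it is the same change, made twice in this set. Among the measured compounds shown here, the only measured instance is the step of a 1.4-fold lower number from compound 1 to compound 2 (0.13 log units; within the scatter), which lies within the scatter.

For the measured compounds named here, on that basis the step from compound 3 to compound 4 in this assay is expected to be of the same small size, a 1.4-fold lower number from compound 3 to compound 4 (0.14 log units; within the scatter), because the one measured instance of this change, a 1.4-fold lower number from compound 1 to compound 2 (0.13 log units; within the scatter), was small. Compound 4 is therefore estimated at 10500 nM, with a range from 5000 nM to 22000 nM, resting on a single comparison and so held loosely.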

Compound 4, half-maximal inhibitory concentration: > 20000 nM
Compound 4 gave a limit, no number; the forecaster's own chance of this, stated with the estimate: 10%; middle value at least 1.9-fold (0.27 log units) from the limit.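

Among the compounds shown here, compound 4 gives a limit of the assay, not a number, and it is the only such reading in the set: the limit of > 20000 nM in this assay, at which 1 of the 4 values shown sits.
Only a floor can therefore be read for the change on the core of compound 3, an at least 1.3-fold higher number from compound 3 to compound 4 (0.13 log units; that floor lies within the scatter), and that floor is small, so nothing here shows a large effect of moving from 2-methylphenyl to 3-methylphenyl on either core.
The data show neither that the step carries over from one core to the other with the same size nor that it fails to do so, and the opposite directions as printed cannot be taken as a real reversal: the same change on two cores in this assay, a 1.4-fold lower number (0.13 log units; within the scatter) from compound 1 to compound 2 and an at least 1.3-fold higher number (0.13 log units; that floor lies within the scatter) from compound 3 to compound 4; the limit leaves it open whether they differ.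

As far as these compounds go, the true size of the step on the core of compound 3 remains open, and with it whether the change behaves alike on both cores in this assay. Also open is whether a carboxylic acid or an amine in place of the methyl on that phenyl would give values that can be read on both cores, since the compounds shown vary only between 2-methylphenyl and 3-methylphenyl.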